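Chloro added to the arylhydrazone of a quinazoline series

The source may report more compounds than this note shows. Statements on the series, on what has been measured and on what is new or still open speak of the compounds shown alone.

The series is built on a quinazoline bearing a hydrazone and a basic side chain. Compound 1 `CN(C)CCNc1nc(N/N=C/c2ccc(F)cc2)nc2ccccc12` carries the shorter side chain; in a functional assay on NCI-H460 cells (Homo sapiens) for cytotoxicity, read by MTT assay, with a stated time of 72 h (a lower number here means a stronger inhibitor, a higher number a weaker inhibitor), compound 1 gives 5680 nM. Compound 2 `CN(C)CCNc1nc(N/N=C/c2ccc(F)cc2Cl)nc2ccccc12` differs from compound 1 by chloro in place of hydrogen on an aromatic carbon, and in this assay compound 2 gives 1760 nM, so the step of a 3.2-fold lower number from compound 1 to compound 2 (0.51 log units; beyond the scatter). Compound 3 `CN(C)CCCNc1nc(N/N=C/c2ccc(F)cc2)nc2ccccc12` differs from compound 1 by (dimethylamino)methyl in place of dimethylamino on a saturated chain carbon, two bonds along the chain from a nitrogen on an aromatic ring; in this assay compound 3 gives 4090 nM, a step of a 1.4-fold lower number from compound 1 to compound 3 (0.14 log units; within the scatter), which leaves compounds 1 and 3 indistinguishable within the scatter.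

Compound 4 `CN(C)CCCNc1nc(N/N=C/c2ccc(F)cc2Cl)nc2ccccc12` has not yet been measured. It differs from compound 3 by chloro in place of hydrogen on an aromatic carbon. This is the same change already seen between compound 1 and compound 2, made this time on the core of compound 3. Since the cores of compound 1 and compound 3 sit within the scatter of each other in this assay, the step observed as a 3.2-fold lower number from compound 1 to compound 2 (0.51 log units; beyond the scatter) is taken as the best guide. The step from compound 3 to compound 4 in this assay is expected to be about a 2.9-fold lower number from compound 3 to compound 4 (0.47 log units; beyond the scatter), resting on the step of a 3.2-fold lower number from compound 1 to compound 2 (0.51 log units; beyond the scatter) and on the value of compound 3, 4090 nM. Compound 4 is therefore estimated at 1400 nM in this assay, with a plausible range from 600 nM to 3500 nM.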

Compound 4, half-maximal inhibitory concentration: 1800 nM
Compound 4: middle estimate off by 1.3-fold (0.11 log units), on the low side; measured number inside the range.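

Carried to the longer side chain, the chloro step holds in this assay, with a 2.3-fold lower number from compound 3 to compound 4 (0.36 log units; beyond the scatter), and it agrees with the step seen on the shorter side chain: the same change on two cores in this assay, a 3.2-fold lower number (0.51 log units; beyond the scatter) from compound 1 to compound 2 and a 2.3-fold lower number (0.36 log units; beyond the scatter) from compound 3 to compound 4, 1.4-fold (0.15 log units) apart, within the scatter of two such steps The side-chain change, (dimethylamino)methyl in place of dimethylamino, stays within the scatter once the chloro is present, with a 1.0-fold higher number from compound 2 to compound 4 (0.01 log units; within the scatter), and it too agrees with its earlier counterpart: the same change on two cores in this assay, a 1.4-fold lower number (0.14 log units; within the scatter) from compound 1 to compound 3 and a 1.0-fold higher number (0.01 log units; within the scatter) from compound 2 to compound 4, 1.4-fold (0.15 log units) apart, within the scatter of two such steps Across these four compounds, the chloro step therefore carries from one core to the other without a detectable loss, but this rests on a single pair of cores, a single substituent and a single cell assay, so it shows neither that the transfer is general nor why the chloro step has this size.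

The compounds shown leave open whether another group in the same place, such as bromo, methyl or methoxy, would carry across these two cores in the same way. They also leave open whether the agreement would survive a longer chain or a ring amine such as morpholine or piperidine in place of the dimethylamino group.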